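Swapping a carboxylic acid for an alcohol on the pyrazole chain

The source may hold more compounds than are shown below. What is called first, only, known or untested is meant among the compounds shown, and "the series" means these compounds.

Of the compounds shown here, three share one core and have been tested in a functional assay on MCF7 cells (Homo sapiens) for antiproliferative activity, read by sulforhodamine B assay, with a stated time of 72 h; a lower number here means a stronger inhibitor, a higher number a weaker inhibitor. Compound 1 `COc1ncc(-c2ccc3ncnc(Nc4ccc(OCCCO)nc4)c3c2)cc1NS(=O)(=O)c1ccc(F)cc1F` gives 6120 nM. Compound 2 `COc1ncc(-c2ccc3ncnc(Nc4cnn(CCC(=O)O)c4)c3c2)cc1NS(C)(=O)=O` gives 560 nM. Compound 3 `COc1ncc(-c2ccc3ncnc(Nc4cnn(CC(=O)O)c4)c3c2)cc1NS(=O)(=O)c1ccc(F)cc1F` gives 700 nM, the second highest of the three numbers; its gap to compound 2 lies within the scatter, whereas the step of an 8.7-fold lower number from compound 1 to compound 3 (0.94 log units; beyond the scatter) is a modest one that lies beyond it.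

Compound 4 `COc1ncc(-c2ccc3ncnc(Nc4cnn(CCCO)c4)c3c2)cc1NS(=O)(=O)c1ccc(F)cc1F` has not yet been measured. It differs from compound 3 only in one spot: 2-hydroxyethyl in place of carboxy on a saturated chain carbon bound to an aromatic nitrogen. For the measured compounds named here, no measured step changes exactly this group. Going by the values given here, the only step available, an 8.7-fold lower number from compound 1 to compound 3 (0.94 log units; beyond the scatter), replaces a whole ring bearing a 3-hydroxypropoxy chain with a pyrazole bearing a carboxymethyl chain, so it mixes two changes and can only hint that the hydroxy-terminated chain of compound 1 went with the weaker number. On that thin basis compound 4 is expected to come out somewhat weaker than compound 3, with a step of a 2.1-fold higher number from compound 3 to compound 4 (0.33 log units; beyond the scatter), and the estimate for compound 4 is 1500 nM, within 500 nM to 5000 nM.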

Compound 4, half-maximal inhibitory concentration: 1310 nM
Estimate against measurement, compound 4: 1.1-fold (0.06 log units) above; low and high end bracket the measured number.
By their numbers in this assay, from the lowest: compounds 2, 3 and 4 (each within the scatter of the next, the first and the last beyond it); then compound 1.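

Moving from the carboxy end to the 2-hydroxyethyl end in this assay gives a 1.9-fold higher number from compound 3 to compound 4 (0.27 log units; within the scatter), so at this spot on the chain a carboxylic acid is not required for a number in this range. The step of a 4.7-fold lower number from compound 1 to compound 4 (0.67 log units; beyond the scatter) keeps a hydroxy-ended chain on both sides, which means that a hydroxy end does not by itself go with the weak number of compound 1; this gap goes with 1-(3-hydroxypropyl)-1H-pyrazol-4-yl in place of 6-(3-hydroxypropoxy)pyridin-3-yl. Nothing available explains either step.

Going by these compounds, whether an amine or a primary amide at the end of this chain would fit with the carboxy and hydroxy ends remains open. The carboxymethyl and 3-hydroxypropyl chains also differ in length, so a 2-hydroxyethyl chain on the pyrazole nitrogen, or a 3-carboxypropyl one, would be needed to separate length from end group.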